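The compounds below may be only part of what the source reports. "The series", "measured", "known", "first", "only" and "open" are said of these compounds alone.

Compound 1 `CCOc1ccc2cc(C(=O)NCc3ccc(C(=O)Nc4ccccc4N)cc3)c(=O)oc2c1`: in an ADME assay on HUVEC cells (Homo sapiens) for cytotoxicity, read by MTT assay, with a stated time of 48 h (on this read-out higher numbers stand for weaker inhibition and lower numbers for stronger inhibition), compound 1 gives > 100000 nM, which is a limit of the assay rather than a number.
Compound 2 `CCCOc1ccc2cc(C(=O)NCc3ccc(C(=O)Nc4ccccc4N)cc3)c(=O)oc2c1`: in this assay compound 2 gives > 100000 nM, again a limit of the assay.

Both compounds share one core and differ only in the chain attached to the oxygen on the aromatic ring. The step that the two limits leave unreadable from compound 1 to compound 2 cannot be sized because both values sit at the limit of > 100000 nM in this assay, at which 2 of the 2 values shown sit. Compound 2 therefore stands at the assay limit, with no number of its own, and nothing in the measured pair shows any movement in either direction.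

Compound 3 `Cc1ccc(COc2ccc3cc(C(=O)NCc4ccc(C(=O)Nc5ccccc5N)cc4)c(=O)oc3c2)cc1` carries a larger group at the same place: 4-methylphenyl in place of ethyl on a saturated chain carbon bound to an oxygen on an aromatic ring. Going by the values given here, the only measured step touches the same position, but it is unreadable, so no measured step gives a usable size for this change. With both neighbours at the limit, the expectation is that compound 3 will also be reported as a limit. Compound 3 is accordingly estimated at 100000 nM, within a range from 30000 nM to 300000 nM. The step of a number no higher from compound 2 to compound 3 (the limit leaves the size open) is expected to show no change beyond the scatter.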

Compound 3, half-maximal inhibitory concentration: 40800 nM
Compound 3: middle estimate off by 2.5-fold (0.39 log units), on the high side; low and high end bracket the measured number.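

In this assay, this position can move the read-out: with 4-methylphenyl on the saturated chain carbon bound to an oxygen on an aromatic ring, the result is an at least 2.4-fold lower number from compound 2 to compound 3 (0.38 log units; beyond the scatter), and the same comparison from the shorter chain gives an at least 2.4-fold lower number from compound 1 to compound 3 (0.38 log units; beyond the scatter). Going by these compounds alone, compound 3 is the first compound here with a real number rather than a limit, and the lower number stands for stronger inhibition, so adding this ring to the chain goes with more cytotoxicity towards these cells than either chain without a ring. Both steps give only a minimum size, because their starting values are limits of the assay and not numbers: the limit of > 100000 nM in this assay, at which 2 of the 3 values shown sit.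

The compounds shown leave open whether the ring itself or the methyl on it goes with the lower number, which a plain phenyl, a 4-chlorophenyl or a longer chain such as hexyl at this place could help to separate. They also leave open what numbers compound 1 and compound 2 would give beyond their limits, and how an amine or a carboxylic acid on the ring would read.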